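Chain Lengthening at a Limit of Cytotoxicity

A few compounds are considered here, and "the series" means these few. Any claim that something is new, unique, unknown or untested is made for them only; others in the source may bear on it.

compound 1 `C[Se]c1nc([Se]C)c2cccnc2n1`: "not determined" (no result reported)
compound 2 `CSc1nc(NCCCc2ccccc2)c2ccccc2n1`: > 100000 nM
compound 3 `Sc1nc(NCc2ccccc2)c2ccccc2n1`: > 100000 nM

In a functional assay on MCF7 cells (Homo sapiens) for cytotoxicity, read by MTT assay, with a stated time of 72 h (on this read-out higher numbers stand for lower toxicity in this test and lower numbers for higher toxicity in this test), compound 2 reports only a limit, > 100000 nM. For compound 3 this assay likewise gives a limit, > 100000 nM. For compound 1 the entry in this assay reads "not determined" (no result reported), so no number stands beside it. Two of the three entries therefore sit at the limit of > 100000 nM in this assay, at which 2 of the 3 values shown sit, and compound 2 stands there too, with no measured number around it against which it could be ranked.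

Compound 4 `CSc1nc(NCCCCc2ccccc2)c2ccccc2n1` is the one not yet measured in this assay. It differs from compound 2 in a single place: benzyl in place of phenyl on a saturated chain carbon, three bonds along the chain from a nitrogen on an aromatic ring. Going by the values given here, no step between two measured compounds is available, so nothing measured shows how a change of this kind moves the read-out, and the expectation rests on compound 2 alone. As compound 2 reaches only a limit in this assay, the step from compound 2 to compound 4 is expected to be a number no higher from compound 2 to compound 4 (the limit leaves the size open), which is to say none beyond the usual scatter. Compound 4 is accordingly expected to give about 100000 nM in this assay, within a range from 40000 nM to 300000 nM, and most likely to be reported again as a limit rather than as a number.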

Compound 4, concentration lethal to 50% of the cells: 95900 nM
For compound 4 the middle estimate is 1.0-fold (0.02 log units) above the measured one; low and high end bracket the measured number.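

With benzyl in place of phenyl on a saturated chain carbon, three bonds along the chain from a nitrogen on an aromatic ring, this position yields the only number rather than a limit among the compounds shown in this assay, and the change amounts to an at least 1.0-fold lower number from compound 2 to compound 4 (0.01 log units; that floor lies within the scatter). Compound 2 stays a limit and not a number: the limit of > 100000 nM in this assay, at which 2 of the 4 values shown sit. The change therefore brings the read-out into the range where a number is reported, yet one end of the step remains a limit, so its true size cannot be read and the printed floor alone establishes no change beyond the scatter.

The compounds shown leave open whether a still longer chain, or an amine or a carboxylic acid in place of the benzyl at this position, would give a number clearly beyond the scatter from compound 4. Going by these compounds alone, they also leave open whether the same change would act alike on another core, since compound 1 and compound 3 differ from compound 4 in more than one place and offer no step for comparison.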